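From sec-butyl to methyl in compound 3

The compounds below may be only part of what the source reports. "The series", "measured", "known", "first", "only" and "open" are said of these compounds alone.

In a functional assay on HBL-100 cells (Homo sapiens) for antiproliferative activity, read by sulforhodamine B assay, with a stated time of 48 h (on this read-out higher numbers stand for weaker inhibition of growth and lower numbers for stronger inhibition of growth), compound 1 (`CCCC(C#CC(=O)OC)O/C=C/C(=O)OC`) gives 270 nM and compound 2 (`CCC(C)C(C#CC(=O)OC)O/C=C/C(=O)OC`) gives 340 nM. For the measured compounds named here, compound 2 thus stands within the scatter of the only other measured compound: a 1.3-fold higher number from compound 1 to compound 2 (0.10 log units; within the scatter). Compound 3 (`COC(=O)C#CC(C)O/C=C/C(=O)OC`) has methyl in place of sec-butyl on a saturated chain carbon bound to an oxygen on an unsaturated carbon and a triple-bonded carbon. Going by the values given here, the sole guide is that measured step, a methyl in place of hydrogen on a saturated chain carbon bound to two saturated chain carbons, and the data hold no direct precedent for this larger change. No shift beyond the scatter is therefore expected, in either direction: the expected step is a 1.0-fold higher number from compound 2 to compound 3 (0.01 log units; within the scatter). Compound 3 is estimated at 350 nM, with an expected range of 120 nM to 1000 nM.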

Compound 3, concentration for 50% growth inhibition: 300 nM
Estimate against measurement, compound 3: 1.2-fold (0.07 log units) above; the range from low to high includes it.
By their numbers in this assay, from the lowest: compounds 1, 3 and 2 (each within the scatter of the next).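

In this assay, methyl in place of sec-butyl on a saturated chain carbon bound to an oxygen on an unsaturated carbon and a triple-bonded carbon gives a 1.1-fold lower number from compound 2 to compound 3 (0.05 log units; within the scatter), and hydrogen in place of ethyl gives a 1.1-fold higher number from compound 1 to compound 3 (0.05 log units; within the scatter). Across compounds 1, 2 and 3, then, removing carbons from this chain, whether branched or straight, leaves the read-out unmoved beyond the scatter. No supporting evidence bears on this result. From the compounds shown here alone, whether a phenyl ring, an amine, a carboxylic acid or a chain longer than sec-butyl at this position would leave the number equally unmoved stays open.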